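The source may hold more compounds than are shown below. What is called first, only, known or untested is meant among the compounds shown, and "the series" means these compounds.

Two compounds with a shared core carry a thiophen-2-yl group on that core and differ only in their amide side chain. Compound 1 `CC(C)CCNC(=O)c1nc(-c2cccs2)[nH]c(=O)c1O` and compound 2 `CC(=O)NCCNC(=O)c1nc(-c2cccs2)[nH]c(=O)c1O` are compared in an assay on isolated protein for inhibition of Flap endonuclease 1 (Homo sapiens); a higher number here means a weaker inhibitor, a lower number a stronger inhibitor. In this assay compound 1 gives 3500 nM, and compound 2 gives 5000 nM. Among the compounds with values here, the only measured step, a 1.4-fold higher number from compound 1 to compound 2 (0.15 log units; within the scatter), lies within the scatter, so compound 1 stands within the scatter of the only other measured compound and the two cannot be told apart.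

Compound 3 `CC(C)CCNC(=O)c1nc(C2CCCCN2C)[nH]c(=O)c1O` is not yet measured. It differs from compound 1 by 1-methylpiperidin-2-yl in place of thiophen-2-yl on an aromatic carbon. Within the data shown here, no measured step touches this part of the core: the one step in hand, from compound 1 to compound 2, changed the amide side chain and left the number within the scatter, which says nothing about swapping the ring on the core. The size and direction of the step in this assay are therefore open, and the estimate carries a wide range. The expected step is a 2.9-fold higher number from compound 1 to compound 3 (0.46 log units; beyond the scatter), leaning toward a higher number. Compound 3 is estimated at 10000 nM, with a range from 2500 nM to 40000 nM.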

Compound 3, half-maximal inhibitory concentration: > 100000 nM
Compound 3 gave a limit, no number; the forecaster's own chance of this, stated with the estimate: 25%; middle value at least 10-fold (1.00 log units) away from the limit.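

The change at this aromatic carbon, para to a hydroxy group, shows what the side-chain step could not: in this assay there is an at least 28-fold higher number from compound 1 to compound 3 (1.45 log units; beyond the scatter), so the group at this place can matter far more than the change in the amide side chain did. The entry for compound 3 is a limit of the assay and not a number, so the step gives only a minimum size for the change: the limit of > 100000 nM in this assay, at which 1 of the 3 values shown sits. The swap also alters several things at once, replacing a five-membered aromatic ring holding sulfur with a six-membered non-aromatic ring holding nitrogen, and this single step cannot show which of these differences matters.

A phenyl group, a cyclohexyl ring or a piperidin-2-yl ring without the methyl group at this place could help separate the effects of losing the aromatic ring, adding the ring nitrogen and carrying its methyl group. From the compounds shown here alone, how the acetamido side chain of compound 2 would behave with 1-methylpiperidin-2-yl on the shared core also stays open.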